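Swapping Phenyl for Allyl on a Triazole Nitrogen

The source may report more compounds than this note shows. Statements on the series, on what has been measured and on what is new or still open speak of the compounds shown alone.

Compound 1 `COc1ccc(-c2nnc(SC/C(=N/O)c3ccccc3)n2-c2ccccc2)cc1` gives 58% in a functional assay on the whole organism (strain albino) for inhibition, with Rattus norvegicus as the target, read by paw edema, with a stated time of 1 h, at a dose of 0.28 mmol/kg by the oral route; on this read-out lower numbers stand for less inhibition and higher numbers for more inhibition at the one dose given (going by the name of the read-out). Compound 2 `COc1ccc(-c2nnc(SCC(=O)c3ccccc3)n2-c2ccccc2)cc1OC` gives 56% in this assay, and compound 3 `C=CCn1c(SCC(=O)c2ccccc2)nnc1-c1ccc(OC)c(OC)c1` gives 61%. Compound 3 differs from compound 2 by allyl in place of phenyl on an aromatic nitrogen. The difference between the cores of compound 1 and compound 2 is not broken down here. Compound 4 `C=CCn1c(SC/C(=N/O)c2ccccc2)nnc1-c1ccc(OC)cc1` has not yet been measured in this assay; it differs from compound 1 by allyl in place of phenyl on an aromatic nitrogen. This is the same kind of change as from compound 2 to compound 3, though the surroundings differ: in compound 1 the ring atoms next to the place bear a 4-methoxyphenyl group and a large group, whereas in compound 2 they bear a (benzoylmethyl)sulfanyl group and a 3,4-dimethoxyphenyl group. Because that earlier change gave a number 5 percentage points higher from compound 2 to compound 3 (within the scatter), compound 4 is expected to show a step of a number 2 percentage points higher from compound 1 to compound 4 (within the scatter), an estimated 60%.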

Compound 4, a percentage reported as inhibition, in the whole organism at one dose (the size of the read-out at that dose, not a potency): 61%
Compound 4: the middle estimate sits 1 percentage points below what was measured; the range from low to high includes it.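

In this assay, allyl in place of phenyl on the aromatic nitrogen gives a number 3 percentage points higher from compound 1 to compound 4 (within the scatter). Set beside the earlier case, the change behaves alike on both cores: the same change on two cores in this assay, a number 5 percentage points higher (within the scatter) from compound 2 to compound 3 and a number 3 percentage points higher (within the scatter) from compound 1 to compound 4, 2 percentage points apart, within the scatter of two such steps. This shows that the swap leaves the number within the usual scatter on these two cores, but it does not show that allyl truly gives more inhibition than phenyl, and two cores make no rule for the whole series.

The compounds shown leave open whether the double bond of allyl matters, as a saturated propyl group on the same nitrogen would test. They also leave open how a longer chain or a chain carrying an amine would read there.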